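Sulfur-to-nitrogen linker swap on a diaminoquinoxaline core

A few compounds are considered here, and "the series" means these few. Any claim that something is new, unique, unknown or untested is made for them only; others in the source may bear on it.

Compound 1, `CCOC(=O)[C@H](CCC(=O)O)NC(=O)c1ccc(Sc2nc3cc(N)cc(N)c3nc2-c2ccccc2)cc1`, in a functional assay on OVCAR-3 cells (Homo sapiens) for inhibition, read by sulforhodamine B assay, with a stated time of 48 h (a lower number here means a stronger inhibitor of growth, a higher number a weaker inhibitor of growth), gives 38000 nM.
Compound 2, `Nc1cc(N)c2nc(-c3ccccc3)c(Sc3ccc(F)cc3)nc2c1`, gives 33900 nM.
Compound 3, `CCOC(=O)[C@H](CCC(=O)O)NC(=O)c1ccc(CNc2nc3cc(N)cc(N)c3nc2-c2ccccc2)cc1`, gives only a limit of the assay, < 100000 nM.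

Among the two numbers at hand, compound 2 sits at the lower one, and compound 1 lies close enough that the two are within the usual scatter; no order can be read between them. Compound 3 is known only as a limit, and the limit of < 100000 nM in this assay, at which 1 of the 3 values shown sits, says no more than that.

The unmeasured compound 4, `Nc1cc(N)c2nc(-c3ccccc3)c(NCc3ccc(F)cc3)nc2c1`, is made from compound 2 by one change: (4-fluorobenzyl)amino in place of (4-fluorophenyl)sulfanyl on an aromatic carbon. For the measured compounds named here, no pair of measured compounds that differ in just one place is available, so the size of this step has not been seen. Compound 4 is expected to fall close to compound 2 or somewhat weaker, with the step of a 1.5-fold higher number from compound 2 to compound 4 (0.17 log units; within the scatter) estimated as modest. The estimate for compound 4 in this assay is 50000 nM, within a range from 15000 nM to 100000 nM, and a sizeable chance that the assay reports only a limit.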

Compound 4, concentration for total growth inhibition: 6460 nM
For compound 4 the middle estimate is 7.7-fold (0.89 log units) above the measured one; the whole stated range lies above it.
By their numbers in this assay, from the lowest: compound 4; then compounds 2 and 1 (each within the scatter of the next).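

At the position next to the ring nitrogen, ortho to a phenyl group, the linker proves to matter: in this assay, (4-fluorobenzyl)amino in place of (4-fluorophenyl)sulfanyl gives a 5.2-fold lower number from compound 2 to compound 4 (0.72 log units; beyond the scatter). The entering group carries a hydrogen-bond donor that the leaving group lacks, but nothing measured here ties the step to that difference or to any other. Compound 3 gives only a limit of the assay, < 100000 nM, so the matching step from compound 1 cannot be read.

Still open, from the compounds shown here alone, is whether the amine nitrogen or the methylene carbon accounts for the step, which a phenylamino or a benzylsulfanyl group at this position would separate. Also open, going by these compounds, is whether the step holds without the fluorine, as with a plain benzylamino group.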